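This account rests on a few compounds, and the source may have more. Where it says the series, first, only, none or still open, it means among the compounds named here.

Measured so far in an assay on LtK cells with ATP-sensitive inward rectifier potassium channel 11 (Homo sapiens) as the target; on this read-out higher numbers stand for an effect only at larger amounts of compound and lower numbers for an effect already at smaller amounts:
compound 1 `CCC(=O)Nc1c(C(O)(C(F)(F)F)C(F)(F)F)ccc2ccccc12`: 15 nM
compound 2 `CCC(CC)C(=O)Nc1c(C(O)(C(F)(F)F)C(F)(F)F)ccc2ccccc12`: 4340 nM
compound 3 `CC(C)CCC(=O)Nc1c(C(O)(C(F)(F)F)C(F)(F)F)ccc2ccccc12`: 49 nM

Compound 3 holds the second highest number of the three, separated from compound 1 by a 3.3-fold higher number from compound 1 to compound 3 (0.51 log units; beyond the scatter) and from compound 2 by an 89-fold lower number from compound 2 to compound 3 (1.95 log units; beyond the scatter).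

Compound 4 `O=C(Nc1c(C(O)(C(F)(F)F)C(F)(F)F)ccc2ccccc12)C1CCCC1` is not yet measured; the change is cyclopentyl in place of isopentyl on a carbonyl carbon. Two measured steps also swap the group on a carbonyl carbon: a 290-fold higher number from compound 1 to compound 2 (2.46 log units; beyond the scatter) was large, an 89-fold lower number from compound 2 to compound 3 (1.95 log units; beyond the scatter) large in the opposite sense, while a 3.3-fold higher number from compound 1 to compound 3 (0.51 log units; beyond the scatter) was modest. The replacement in compound 4 resembles the former more than the latter, so a step upward beyond the scatter is expected, a 14-fold higher number from compound 3 to compound 4 (1.15 log units; beyond the scatter), though smaller than that seen for compound 2.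

Compound 4 is therefore estimated at 700 nM, with a range of 120 nM to 4000 nM.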

Compound 4, half-maximal effective concentration: 495 nM
Estimate against measurement, compound 4: 1.4-fold (0.15 log units) above, within the range that was stated.
By their numbers in this assay, from the lowest: compound 1; then compound 3; then compound 4; then compound 2.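

Swapping isopentyl for cyclopentyl on the carbonyl carbon keeps the heavy-atom count but closes a ring, and this alone gives a clear change (a 10-fold higher number from compound 3 to compound 4 (1.00 log units; beyond the scatter)). Compound 4 falls short of ethyl (a 33-fold higher number from compound 1 to compound 4 (1.52 log units; beyond the scatter)) but recovers part of the loss seen with pentan-3-yl (an 8.8-fold lower number from compound 2 to compound 4 (0.94 log units; beyond the scatter)), so the four groups rank ethyl, isopentyl, cyclopentyl, pentan-3-yl from lowest number to highest. No measured data explain this order.

Open, as far as these compounds go, is whether methyl or a straight butyl chain would match ethyl. Also open, from the compounds shown here alone, is how cyclopropyl or cyclohexyl would compare with cyclopentyl.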